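The compounds below may be only part of what the source reports. "The series", "measured", "known", "first", "only" and "open" are said of these compounds alone.

Of the compounds shown here, three of this set have been measured. Compound 1 `COc1cc(C2CC(c3ccccc3)=NN2C(C)=O)ccc1OCc1cn(Cc2ccc([N+](=O)[O-])cc2)nn1` gives 0% in a functional assay on THP-1 cells (Homo sapiens) for inhibition, read by sulforhodamine B assay, tested at 10 uM; on this read-out higher numbers stand for more inhibition of growth at the one concentration tested and lower numbers for less inhibition of growth. Compound 2 `COc1cc(C2CC(c3cc(OC)c(OC)c(OC)c3)=NN2C(C)=O)ccc1OCc1cn(Cc2ccc([N+](=O)[O-])cc2)nn1`, which carries a 3,4,5-trimethoxyphenyl group instead, gives 29%, and the step is a number 29 percentage points higher from compound 1 to compound 2 (beyond the scatter). Compound 3 `COc1cc(C2CC(c3cccc4ccccc34)=NN2C(C)=O)ccc1OCc1cn(Cc2ccc([N+](=O)[O-])cc2)nn1`, with a naphthalen-1-yl group in the same place, gives 10%. Among the three numbers compound 3 stands second; its step from compound 1 is a number 10 percentage points higher from compound 1 to compound 3 (within the scatter), while the step from compound 2 is a number 19 percentage points lower from compound 2 to compound 3 (beyond the scatter).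

Compound 4 `COc1cc(C2CC(c3ccc(Cl)cc3)=NN2C(C)=O)ccc1OCc1cn(Cc2ccc([N+](=O)[O-])cc2)nn1` differs from compound 3 in one place: 4-chlorophenyl in place of naphthalen-1-yl on a carbon with a double bond to nitrogen. Going by the values given here, no measured step involves a 4-chlorophenyl group, so the expectation rests on the two steps that involve the naphthalen-1-yl group. Among the compounds with values here, replacing phenyl by naphthalen-1-yl moved the number only within the scatter, and the trimethoxyphenyl group gave the one clearly higher number. Returning to a single ring with one chlorine is therefore expected to give a step of a number 2 percentage points lower from compound 3 to compound 4 (within the scatter), that is, no change beyond the scatter. Compound 4 is estimated at 8%, with a range from 0% to 25%.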

Compound 4, percent growth inhibition at one concentration: 17%
Beside the measured number, compound 4's estimate is 9 percentage points below it, and the stated range covers the measured number.
By their numbers in this assay, from the lowest: compounds 1, 3 and 4 (each within the scatter of the next, the first and the last beyond it); then compound 2.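

Replacing hydrogen with chloro on an aromatic carbon of the phenyl group gives a step that can be read in this assay (a number 17 percentage points higher from compound 1 to compound 4 (beyond the scatter)), so even one added chlorine can register at this position. The 4-chlorophenyl and naphthalen-1-yl groups cannot be told apart (a number 7 percentage points higher from compound 3 to compound 4 (within the scatter)), while the 3,4,5-trimethoxyphenyl group remains clearly ahead of 4-chlorophenyl (a number 12 percentage points lower from compound 2 to compound 4 (beyond the scatter)) and now stands above all three other groups. Nothing available here explains these differences.

From the compounds shown here alone, it remains open whether a single methoxy group, as in 4-methoxyphenyl, would account for part of the higher number seen with three of them. A 4-aminophenyl or 4-carboxyphenyl group at this position would show how groups other than chloro and methoxy fare on the same ring.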